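A few compounds are considered here, and "the series" means these few. Any claim that something is new, unique, unknown or untested is made for them only; others in the source may bear on it.

Measured compounds:
compound 1 `O=C(CCc1ccccc1)Nc1nc2ccccc2c(=O)s1` gives 42.7 nM in an assay on mitochondria (strain Sprague-Dawley) for inhibition of Amine oxidase [flavin-containing] B (Rattus norvegicus), read by fluorescence and Amplex Red, with stated times of 30 min and 45 min; on this read-out lower numbers stand for stronger inhibition and higher numbers for weaker inhibition;
compound 2 `O=C(CCCc1ccccc1)Nc1nc2ccccc2c(=O)s1` gives 186 nM in this assay;
compound 3 `O=C(CCc1ccccc1Br)Nc1nc2ccccc2c(=O)s1` gives 64 nM in this assay.

Compound 4 `O=C(CCCc1ccccc1)Nc1nc2ccc(Br)cc2c(=O)s1` has not yet been measured. Among the compounds with values here, compound 2 and compound 4 share a core; that core differs from the one in compound 1 and compound 3 by benzyl in place of phenyl on a saturated chain carbon, two bonds along the chain from a carbonyl carbon, a change that gave a 4.4-fold higher number from compound 1 to compound 2 (0.64 log units; beyond the scatter). Between compound 1 and compound 3 the change is bromo in place of hydrogen on an aromatic carbon, and it made a 1.5-fold higher number from compound 1 to compound 3 (0.18 log units; within the scatter). Between compound 2 and compound 4 the change is bromo in place of hydrogen on an aromatic carbon. It is the same kind of change, but not the same: in compound 3 the bromo sits ortho to a large group, while in compound 4 it sits on a fused or bridged system of two rings, meta and para to a fused ring. Because the earlier step of a 1.5-fold higher number from compound 1 to compound 3 (0.18 log units; within the scatter) stayed within the scatter, the step from compound 2 to compound 4 is expected to be similarly small, a 1.2-fold higher number from compound 2 to compound 4 (0.09 log units; within the scatter), though the different place leaves room for doubt. Compound 4 is therefore estimated at 230 nM, likely between 90 nM and 600 nM.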

Compound 4, half-maximal inhibitory concentration: > 10000 nM
Compound 4: only a limit was reported (the forecaster's own chance of this, stated with the estimate: 5%); at least 43-fold (1.63 log units) between middle value and limit.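

In this assay compound 4 gives > 10000 nM, which is a limit of the assay and not a number. The swap of hydrogen for bromo produced an at least 53-fold higher number from compound 2 to compound 4 (1.73 log units; beyond the scatter), and it did not behave alike on the two cores: the same change on two cores in this assay, a 1.5-fold higher number (0.18 log units; within the scatter) from compound 1 to compound 3 and an at least 53-fold higher number (1.73 log units; beyond the scatter) from compound 2 to compound 4, at least 35-fold (1.55 log units) apart, beyond the scatter of two such steps This shows that a bromo step read on one core cannot simply be carried over to another in this series, but it does not show what sets the two steps apart, as they differ both in the core and in where the bromo sits, and the limit leaves the full size of the new step unknown.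

The compounds shown leave open whether bromo at the place it holds in compound 4 would also bring such a large step on the core of compound 1, which would separate the effect of the chain from that of the place. On these data alone, it also remains open whether a fluoro or a methoxy group at that same place would be tolerated better than bromo.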